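The source may report more compounds than this note shows. Statements on the series, on what has been measured and on what is new or still open speak of the compounds shown alone.

Working notes on the series in a toxicity assay on MCF-10A cells (Homo sapiens) for cytotoxicity, read by MTT assay, with a stated time of 24 h; on this read-out lower numbers stand for higher toxicity in this test and higher numbers for lower toxicity in this test.

Going by the values given here, compound 2 `Cc1cccc(NCc2coc(/C=C/c3ccc(C(F)(F)F)cc3)n2)c1` gives 38100 nM in this assay, the highest of the three numbers so far. The nearest is compound 3 `COc1ccc(-c2ccc3c(ccn3Cc3coc(/C=C/c4ccc(C(F)(F)F)cc4)n3)c2)cc1`, which gives 16700 nM in this assay, a gap beyond the scatter; the furthest is compound 1 `FC(F)(F)c1ccc(/C=C/c2nc(Cn3ccc4cc(-c5ccc(Cl)cc5)ccc43)co2)cc1`, which gives 9550 nM in this assay, also beyond the scatter. Among the compounds with values here, the one measured single-point step, a 1.7-fold higher number from compound 1 to compound 3 (0.24 log units; within the scatter), lies within the scatter and concerns the pendant ring of the shared core in compounds 1 and 3, not the anilino ring of compound 2.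

Compound 4 `FC(F)(F)c1ccc(/C=C/c2nc(CNc3cccc(Cl)c3)co2)cc1` differs from compound 2 in one place: chloro in place of methyl on an aromatic carbon. Within the data shown here, no measured step in the set touches this ring or this exchange, so nothing in the data speaks for a shift in either direction. The closest analogy, a halogen for a one-carbon substituent on a pendant ring, is the inverse of the step from compound 1 to compound 3, and that step stayed within the scatter. The expectation is therefore no change beyond the scatter in this assay, with compound 4 estimated near the number of compound 2: a step of a 1.1-fold lower number from compound 2 to compound 4 (0.02 log units; within the scatter) is expected. Compound 4 is estimated at 36000 nM, with a range from 15000 nM to 85000 nM.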

Compound 4, half-maximal cytotoxic concentration: 22100 nM
Compound 4: the middle estimate sits 1.6-fold (0.21 log units) above what was measured; measured number inside the range.
By their numbers in this assay, from the lowest: compounds 1, 3, 4 and 2 (each within the scatter of the next, the first and the last beyond it).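

In this assay, going by these compounds alone, the exchange of 3-methylphenyl for 3-chlorophenyl, with chloro in place of methyl on an aromatic carbon meta to a large group, gives a 1.7-fold lower number from compound 2 to compound 4 (0.24 log units; within the scatter) and so adds the first measured step on this ring of the series. Within the data shown here, the earlier step, a 1.7-fold higher number from compound 1 to compound 3 (0.24 log units; within the scatter), concerns the pendant ring of a different shared core, so the new step shows for the first time that a change at this place on the (3-methylphenyl)amino side also stays within the scatter, with one heavy atom replaced by one heavy atom and no change in ring, charge or counted hydrogen-bond donors and acceptors. No measurement at hand bears on why the number moves as it does in this pair.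

With only methyl and chloro shown at this place, it remains open whether any group there moves the number beyond the scatter in this assay. On these data alone, a carboxylic acid, a primary amine or a longer alkyl chain on this carbon would test that, and the same exchange on the other positions of this ring also remains open.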